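Fluoro for Methoxy in a Cytotoxicity Series

The compounds below may be only part of what the source reports. "The series", "measured", "known", "first", "only" and "open" are said of these compounds alone.

Three compounds have numbers in an ADME assay on THP-1 cells (Homo sapiens) for cytotoxicity, read by flow cytometry and propidium iodide staining, with a stated time of 72 h; on this read-out lower numbers stand for stronger inhibition and higher numbers for weaker inhibition. Compound 1 (`Nc1ccc2oc(-c3cccc(F)c3)cc(=O)c2c1`) reports only a limit, > 125000 nM. In this assay compound 2 (`CC(=O)Nc1ccc2oc(-c3cccc(F)c3)c(O)c(=O)c2c1`) gives 36000 nM. Compound 3 (`COc1cccc(-c2oc3ccc(N)cc3c(=O)c2O)c1`) gives 2000 nM, the lower of the two actual numbers, and its gap to compound 2 lies beyond the scatter. Compound 4 (`Nc1ccc2oc(-c3cccc(F)c3)c(O)c(=O)c2c1`) has fluoro in place of methoxy on an aromatic carbon. Within the data shown here, no measured pair shows this change alone. Compound 2 also carries the fluoro and gives 36000 nM, but it differs from compound 4 elsewhere, so it only tilts the expectation towards a higher number. A small rise near the edge of the scatter is expected in this assay, an estimated 2.0-fold higher number from compound 3 to compound 4 (0.30 log units; within the scatter). Compound 4 is expected at 4000 nM, within an estimated range of 1000 nM to 16000 nM.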

Compound 4, half-maximal inhibitory concentration: 30000 nM
Compound 4: the middle estimate sits 7.5-fold (0.88 log units) below what was measured; measured number above the stated range.
By their numbers in this assay, from the lowest: compound 3; then compounds 4 and 2 (each within the scatter of the next). At a limit, above all of these: compound 1.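

In this assay, this aromatic carbon matters: fluoro in place of methoxy gives a 15-fold higher number from compound 3 to compound 4 (1.18 log units; beyond the scatter). By contrast, hydrogen in place of acetyl on a nitrogen gives a 1.2-fold lower number from compound 2 to compound 4 (0.08 log units; within the scatter), which stays within the scatter. Hydroxy in place of hydrogen on an aromatic carbon gives an at least 4.1-fold lower number from compound 1 to compound 4 (0.61 log units; beyond the scatter), and that step rests on a limit rather than a number: the limit of > 125000 nM in this assay, at which 1 of the 4 values shown sits.

The compounds shown leave open whether an ethoxy or a chloro on that carbon would sit nearer compound 3 or compound 4. They also leave open whether methoxy would keep its lower number with an acetyl on the nitrogen.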